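A few compounds are considered here, and "the series" means these few. Any claim that something is new, unique, unknown or untested is made for them only; others in the source may bear on it.

Of the compounds shown here, three built on one shared core have so far been measured in a functional assay on SK-BR-3 cells (Homo sapiens) for antiproliferative activity; a lower number here means a stronger inhibitor, a higher number a weaker inhibitor. Compound 1 `CC(=O)Oc1ccc(C(=O)Nc2cc3ccc(OCC4CCCN(C)C4)c(C)c3oc2=O)cc1CC=C(C)C` gives 740 nM. Compound 2 `CC(=O)Oc1ccc(C(=O)Nc2cc3ccc(OCC4CCCNC4)c(C)c3oc2=O)cc1CC=C(C)C` gives 620 nM. Compound 3 `CCN(C)CCCOc1ccc2cc(NC(=O)c3ccc(O)c(CC=C(C)C)c3)c(=O)oc2c1C` gives 730 nM. On these numbers compound 3 sits alongside compound 1 and compound 2, so close to both that no order among the three can be read from the data. For the measured compounds named here, the single one-point comparison available, a 1.2-fold lower number from compound 1 to compound 2 (0.08 log units; within the scatter), came from putting hydrogen in place of methyl on an amine nitrogen in a ring, and it left the number inside the scatter.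

Compound 4 `CC(C)=CCc1cc(C(=O)Nc2cc3ccc(OCCCN(C)C(C)(C)C)c(C)c3oc2=O)ccc1O` has not yet been measured. It differs from compound 3 in one place only: tert-butyl in place of ethyl on an amine nitrogen. Like the one measured step, this change touches a group carried on an amine nitrogen, and that measured step stayed within the scatter. The change here is bulkier, tert-butyl entering for ethyl, but nothing measured speaks to such a swap directly. The step of a 1.1-fold higher number from compound 3 to compound 4 (0.04 log units; within the scatter) is therefore expected to stay within the scatter, with no clear direction. Compound 4 is estimated at 800 nM, in a range from 350 nM to 1800 nM, and the measurement will show whether that holds.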

Compound 4, half-maximal inhibitory concentration: 880 nM
For compound 4 the middle estimate is 1.1-fold (0.04 log units) below the measured one, and the stated range covers the measured number.
By their numbers in this assay, from the lowest: compounds 2, 3, 1 and 4 (each within the scatter of the next).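

Replacing ethyl with tert-butyl on an amine nitrogen gives a 1.2-fold higher number from compound 3 to compound 4 (0.08 log units; within the scatter) in this assay, so a group of 4 heavy atoms can stand in place of one of 2 on this nitrogen, with methyl as its other small group, without the number leaving the scatter. For the compounds shown here, the earlier compounds offered only one change at an amine nitrogen, hydrogen in place of methyl on a nitrogen in a ring, which gave a 1.2-fold lower number from compound 1 to compound 2 (0.08 log units; within the scatter); the new step adds a second, different kind of change, this time on a nitrogen in an open chain, and within these four compounds both steps stay inside the scatter. No separate measurement bears on this result.

The compounds shown leave open whether hydrogen, a hydroxyethyl group or a group carrying a carboxylic acid in place of ethyl on this nitrogen would move the number beyond the scatter. Whether the amine nitrogen itself matters also stays open, since every compound shown carries one, and an amide in its place would put that question to the test.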